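A few compounds are considered here, and "the series" means these few. Any claim that something is new, unique, unknown or untested is made for them only; others in the source may bear on it.

Compound 1 `COc1ccc(CS(=O)(=O)/C=C/c2ccccc2OC)cc1` gives 5000 nM in a functional assay on BT-20 cells (Homo sapiens) for antiproliferative activity, read by trypan blue exclusion (on this read-out higher numbers stand for weaker inhibition and lower numbers for stronger inhibition), the higher of the two plain numbers shown. Compound 2 `COc1ccc(CS(=O)(=O)/C=C/c2c(OC)cccc2OC)cc1` gives 400 nM. Compound 3 `COc1ccc(CS(=O)(=O)/C=C/c2ccc(OC)cc2OC)cc1` is reported only as a limit of the assay, > 20000 nM (the limit of > 20000 nM in this assay, at which 1 of the 3 values shown sits). Compound 4 `COc1ccc(CS(=O)(=O)/C=C/c2cc(OC)ccc2OC)cc1` differs from compound 1 by methoxy in place of hydrogen on an aromatic carbon. Among the measured compounds shown here, two measured steps bear on this change, each also placing a methoxy group on the same ring of compound 1, but at a different place: a 13-fold lower number from compound 1 to compound 2 (1.10 log units; beyond the scatter) and an at least 4.0-fold higher number from compound 1 to compound 3 (0.60 log units; beyond the scatter). These two steps run in opposite directions, so the step of no change at the digits printed from compound 1 to compound 4 (within the scatter) in this assay is expected to be small, with a wide range in either direction. Compound 4 is therefore estimated at 5000 nM, within 1000 nM to 25000 nM.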

Compound 4, half-maximal inhibitory concentration: > 20000 nM
Compound 4: a limit, no number; the forecaster's own chance of this, stated with the estimate: 25%; at least 4.0-fold (0.60 log units) between middle value and limit.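

In this assay, a methoxy group placed meta to a large group and para to a methoxy group goes with weaker inhibition, an at least 4.0-fold higher number from compound 1 to compound 4 (0.60 log units; beyond the scatter), the same direction as the step to compound 3. Of the three placements on this ring, only compound 2 moves the other way, a 13-fold lower number from compound 1 to compound 2 (1.10 log units; beyond the scatter). Compound 4 and compound 3 are both reported as limits, so neither rise has a size and the two cannot be ordered: the limit of > 20000 nM in this assay, at which 2 of the 4 values shown sit.

The compounds shown leave open whether the rise belongs to methoxy itself. A hydroxyl, an amine or a fluorine at this position might behave differently.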